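A few compounds are considered here, and "the series" means these few. Any claim that something is new, unique, unknown or untested is made for them only; others in the source may bear on it.

Measured compounds:
- compound 2 `ClCc1ccccc1Cn1cnc2c(Cl)nc(Cl)nc21`: 2810 nM
- compound 1 `ClCc1ccc(Cn2cnc3c(Cl)ncnc32)cc1`: 15100 nM

These two compounds were tested in a functional assay on OVCAR-8 cells (Homo sapiens) for cytotoxicity, read by sulforhodamine B assay, with a stated time of 48 h; a higher number here means a weaker inhibitor of growth, a lower number a stronger inhibitor of growth. Compound 2 stands at the lower of the two numbers, so it is the stronger inhibitor of growth of the pair; compound 1 gives a number that is higher by a margin that lies beyond the scatter of repeated measurements. Compound 1 and compound 2 differ in more than one respect, so that comparison alone does not isolate any single change.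

The next compound, compound 3 `ClCc1ccccc1Cn1cnc2c(Cl)ncnc21`, has not yet been measured in this assay. It differs from compound 2 by hydrogen in place of chloro on an aromatic carbon. For the measured compounds named here, no measured pair isolates this particular change, so the direction of the step can only be guessed from the shared core. Going by the values given here, because compound 1, which also carries only one chloro on its core, gives 15100 nM, a somewhat weaker inhibition of growth than compound 2 is expected for compound 3, though with wide uncertainty.

The step from compound 2 to compound 3 is estimated as a 2.5-fold higher number from compound 2 to compound 3 (0.40 log units; beyond the scatter). For compound 3 the expected value in this assay is 7000 nM, with a range from 2500 nM to 20000 nM.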

Compound 3, concentration for total growth inhibition: 5240 nM
The estimate for compound 3 lay 1.3-fold (0.13 log units) above the measured number; the range from low to high includes it.
By their numbers in this assay, from the lowest: compounds 2 and 3 (each within the scatter of the next); then compound 1.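

In this assay, for the compounds shown here, replacing chloro with hydrogen on the aromatic carbon between two ring nitrogen atoms gives a 1.9-fold higher number from compound 2 to compound 3 (0.27 log units; within the scatter), and this is the first measured pair that isolates this single change. At this position, the two compounds cannot be told apart beyond the ordinary spread of repeated measurements, so the chloro group is not needed here to keep growth inhibition at this level in these cells. Going by these compounds alone, nothing measured so far explains why the two compounds read alike.

The compounds shown leave open whether a different group on this same carbon, such as an amine, a methoxy group or a nitrile, would shift the number beyond the scatter, since chloro and hydrogen are the only two groups compared here. They also leave open what the remaining chloro group on the shared core and the chloromethyl group on the benzene ring each contribute, which could be tested by replacing the first with an amine and the second with a hydroxymethyl group.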